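The source may hold more compounds than are shown below. What is called first, only, known or untested is meant among the compounds shown, and "the series" means these compounds.

Among the measured compounds shown here, compound 2 `O=C(O)c1cc2cc([N+](=O)[O-])ccc2n1CCCc1ccccc1` is one of three compounds measured in an assay on cells (Oocyte) for inhibition of pannexin-1 (Mus musculus), read by voltage clamp, tested at 50 uM, in the presence of a further agent that is not named here; a higher number here means more inhibition at the concentration tested (going by the name of the read-out), a lower number less inhibition. In this assay compound 2 gives 65.5%, which places it second highest of the three numbers. Compound 1 `O=C(O)c1cn(CCCCc2ccccc2)c2ccc([N+](=O)[O-])cc12`, in this assay, gives 65.7%, and the gap to compound 2 lies within the scatter of the measurement, so the two cannot be ranked against each other. Compound 3 `O=C(O)c1ccc(Cn2cc(C(=O)O)c3cc([N+](=O)[O-])ccc32)cc1`, in this assay, gives 54%, and here the gap to compound 2 lies beyond the scatter.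

Compound 4 `O=C(O)c1cc2cc([N+](=O)[O-])ccc2n1Cc1ccccc1` has not yet been measured. It differs from compound 2 in one place: phenyl in place of phenethyl on a saturated chain carbon bound to an aromatic nitrogen. For the measured compounds named here, no pair of measured compounds differs in a single place, so the size of this step has not been seen directly; the only guide is that the compounds with a longer chain between the core and the phenyl ring, compound 1 and compound 2, gave the higher numbers, while compound 3, whose chain is a single carbon, gave the lower one. On that basis a small decrease in this assay is expected from compound 2 to compound 4, of the order of a number 8.5 percentage points lower from compound 2 to compound 4 (within the scatter), which may well lie within the scatter. Compound 4 is estimated to give about 57% in this assay, with a range from 42% to 70%.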

Compound 4, a percentage reported as inhibition, at one concentration (the size of the read-out at that concentration, not a potency): 51.3%
Compound 4: the middle estimate sits 5.7 percentage points above what was measured; the range from low to high includes it.
By their numbers in this assay, from the lowest: compounds 4 and 3 (each within the scatter of the next); then compounds 2 and 1 (each within the scatter of the next).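

Among the compounds shown here, the step of a number 14.2 percentage points lower from compound 2 to compound 4 (beyond the scatter) is the first change in a single place seen, and it shows that the group on this saturated chain carbon bound to an aromatic nitrogen affects the read-out in this assay. Both groups hold one six-membered aromatic ring of carbon only, with no hydrogen-bond donors or acceptors and no net charge, so the listed difference between phenethyl and phenyl is one of carbon count alone; even so, compound 4 keeps a measurable inhibition of 51.3%, so the change reduces the number without removing it. Nothing given here accounts for the size of this step.

The compounds shown leave open whether a longer chain at this place would raise the number further or leave it level, and whether an amine or a hydroxyl group on the chain would behave as the plain carbon chain does. Since each number comes from a single tested concentration, they also leave open whether this step would carry over to a difference in potency.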